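The source may hold more compounds than are shown below. What is called first, only, known or untested is meant among the compounds shown, and "the series" means these compounds.

Compound 1, `CCN(CC)CCCC(C)/N=C(/N)NC(=O)c1cccc(F)c1OCc1cc(Br)ccc1OC`, gives 900 nM in an assay for binding affinity to Melanocortin receptor 4 (Homo sapiens); a higher number here means a weaker inhibitor, a lower number a stronger inhibitor.
Compound 2, `COc1ccc(Br)cc1CCc1c(F)cccc1C(=O)/N=C(\N)NCCN1CCCC1`, gives 190 nM in this assay.
Compound 3, `CCCC/N=C(/N)NC(=O)c1cccc(F)c1CCc1cc(Br)ccc1OC`, gives 920 nM in this assay.

Of these three, compound 2 has the lowest number in this assay, and its gaps to compound 1 and to compound 3 both lie beyond the usual scatter, so compound 2 is the strongest binder of the three. Compound 1 and compound 3 sit close to each other.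

Compound 4, `COc1ccc(Br)cc1CCc1c(F)cccc1C(=O)/N=C(\N)NCC1CCNCC1`, has not yet been measured. It differs from compound 2 in a single place: piperidin-4-yl in place of (pyrrolidin-1-yl)methyl on a saturated chain carbon bound to an amine nitrogen. The two share every atom; only the joining of the ring-bearing tail to the chain differs. Within the data shown here, no measured pair in this set shows a change of this kind, so there is nothing here to say how large such a step tends to be, or in which direction. With the rest of the molecule unchanged, the expectation is a step of modest size from compound 2 to compound 4 in this assay, most likely within or only slightly beyond the scatter.

Compound 4 is therefore estimated at 260 nM in this assay, with a range from 80 nM to 850 nM, which corresponds to an expected step of a 1.4-fold higher number from compound 2 to compound 4 (0.14 log units; within the scatter).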

Compound 4, inhibition constant: 13 nM
Compound 4: the middle estimate sits 20-fold (1.30 log units) above what was measured; measured number outside the range, below it.
By their numbers in this assay, from the lowest: compound 4; then compound 2; then compounds 1 and 3 (each within the scatter of the next).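

Among these compounds, until now, no two compounds differed in only one place, so nothing showed how much a single part of these molecules matters. In this assay, exchanging (pyrrolidin-1-yl)methyl for piperidin-4-yl on a saturated chain carbon bound to an amine nitrogen gives a 15-fold lower number from compound 2 to compound 4 (1.16 log units; beyond the scatter) and shows that this place responds strongly even when no atom is added or removed: the way the same atoms are joined is enough for a large step beyond the scatter. The change alters two things at once, a five-membered ring becoming a six-membered ring and a hydrogen-bond donor appearing in the entering group, and no measurement shown here explains the step.

Which of those two differences goes with the step remains open, as does whether it would appear with the other chains seen in compound 1 and compound 3. A (pyrrolidin-3-yl)methyl group, which keeps the five-membered ring but has a hydrogen on its ring nitrogen, and a piperidin-4-yl group with a methyl on that nitrogen would help to separate the two differences.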